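Cyclopropyl for Benzyl on the Amide Nitrogen

This account rests on a few compounds, and the source may have more. Where it says the series, first, only, none or still open, it means among the compounds named here.

Measured compounds:
compound 1, `O=C(NC1CC1)c1cc(Oc2ccc(/C=C/c3ccccn3)cc2)ccn1`, 17300 nM
compound 2, `O=C(NCc1ccccc1)c1cc(Oc2ccc(/C=C/c3ccncc3)cc2)ccn1`, 17000 nM

Of the compounds shown here, two have been measured in a functional assay on A549 cells (Homo sapiens) for antiproliferative activity, read by CCK-8 assay, with a stated time of 48 h; on this read-out lower numbers stand for stronger inhibition and higher numbers for weaker inhibition. Compound 1 gives 17300 nM in this assay. Compound 2 gives 17000 nM in this assay, and the two numbers lie within the scatter of each other, so neither compound can be set apart from the other on this read-out. Compound 2 therefore stands level with compound 1 among the numbers shown.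

The step to be examined leads from compound 2 to compound 3, `O=C(NC1CC1)c1cc(Oc2ccc(/C=C/c3ccncc3)cc2)ccn1`. The change is cyclopropyl in place of benzyl on an amide-type nitrogen. Among the compounds with values here, no step between measured compounds that differ in one place is available, so the size of the change cannot be read from a measured pair. Compound 1 carries the same cyclopropyl group on the amide-type nitrogen and is within the scatter of compound 2, which gives no sign of a shift in either direction.

The change from compound 2 to compound 3 is therefore expected to give no step beyond the scatter in this assay, no change at the digits printed from compound 2 to compound 3 (within the scatter). Compound 3 is estimated at 17000 nM, with a range from 6000 nM to 50000 nM.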

Compound 3, half-maximal inhibitory concentration: 35500 nM
Estimate against measurement, compound 3: 2.1-fold (0.32 log units) below; the range from low to high includes it.
By their numbers in this assay, from the lowest: compounds 2 and 1 (each within the scatter of the next); then compound 3.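

In this assay, the amide-type nitrogen proves not to be a silent place: with the rest of the structure unchanged, cyclopropyl in place of benzyl gives a 2.1-fold higher number from compound 2 to compound 3 (0.32 log units; beyond the scatter), so here benzyl goes with the stronger inhibition. The pyridine attachment also registers once cyclopropyl is held on that nitrogen, since pyridin-4-yl in place of pyridin-2-yl gives a 2.1-fold higher number from compound 1 to compound 3 (0.31 log units; beyond the scatter), and compound 3 thus stands apart from each of its two single-change neighbours, both steps being modest. Nothing at hand explains either step.

The compounds shown leave open whether the benzyl result depends on its aromatic ring or simply on the larger group, a question that a cyclohexylmethyl group, a plain cyclohexyl group or a longer phenylethyl chain on the amide-type nitrogen would address. They also leave open whether the benzyl step would keep its direction and size with pyridin-2-yl in place of pyridin-4-yl, and whether a group such as an amine or a carboxylic acid on the benzyl ring would shift the number at all.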